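The source may hold more compounds than are shown below. What is called first, only, known or untested is meant among the compounds shown, and "the series" means these compounds.

Measured so far in a functional assay on HT-29 cells (Homo sapiens) for cytotoxicity, read by MTT assay, with a stated time of 72 h; a higher number here means a weaker inhibitor, a lower number a stronger inhibitor:
Compound 1 `COc1ccc(-c2cc(/N=C3/NC(=O)CS3)cs2)cc1`: here compound 1 gives only a limit, > 50000 nM.
Compound 2 `O=C1CS/C(=N\c2csc(-c3ccccc3)c2)N1`: here compound 2 gives only a limit, > 50000 nM.
Compound 3 `O=C1CS/C(=N\c2csc(-c3ccc(Cl)cc3)c2)N1`: here compound 3 gives 17100 nM.

Going by the values given here, compound 3 thus carries the only number in the set; the other two values sit at the limit of > 50000 nM in this assay, at which 2 of the 3 values shown sit. The steps of an at least 2.9-fold lower number from compound 1 to compound 3 (0.46 log units; beyond the scatter) and an at least 2.9-fold lower number from compound 2 to compound 3 (0.46 log units; beyond the scatter) both lower the number, while a step that the two limits leave unreadable from compound 1 to compound 2 cannot be read.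

Compound 4 `Cc1ccc(N2C(=O)CS/C2=N\c2csc(-c3ccc(Cl)cc3)c2)cc1` keeps the chloro substituent of compound 3 and differs from it by 4-methylphenyl in place of hydrogen on an amide-type nitrogen in a ring. Among the compounds with values here, none of the measured steps touches this ring nitrogen, so they give no direction for the change. The expectation is therefore a step of a 1.1-fold lower number from compound 3 to compound 4 (0.06 log units; within the scatter), within the scatter. Compound 4 is estimated at 15000 nM in this assay, with a range from 4000 nM to 50000 nM.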

Compound 4, half-maximal inhibitory concentration: 28900 nM
Beside the measured number, compound 4's estimate is 1.9-fold (0.28 log units) below it; the measured number falls inside the stated range.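

In this assay, going by these compounds alone, the first change at the amide-type nitrogen in a ring, 4-methylphenyl in place of hydrogen, gives a 1.7-fold higher number from compound 3 to compound 4 (0.23 log units; within the scatter), so this position carries an aromatic ring with no step beyond the scatter while the chloro substituent stays. Compound 4 also stays readable as a number and does not join the compounds held at the limit: the limit of > 50000 nM in this assay, at which 2 of the 4 values shown sit.

Open, as far as these compounds go, is how a small alkyl group such as methyl, or a chain ending in an amine or a carboxylic acid, would read on this nitrogen. Also open, from the compounds shown here alone, is whether 4-methylphenyl there would read the same with methoxy or hydrogen in place of chloro.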